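The compounds below may be only part of what the source reports. "The series", "measured", "known", "first", "only" and "open" are said of these compounds alone.

In a functional assay on DU-145 cells (Homo sapiens) for inhibition, read by trypan blue exclusion, with a stated time of 96 h; a lower number here means a stronger inhibitor of growth, a higher number a weaker inhibitor of growth:
- Compound 1 `O=C(/C(=C\c1cc(Cl)cc(Cl)c1Cl)S(=O)(=O)Cc1ccc(Cl)cc1)c1ccc(Br)cc1`: 1000 nM
- Compound 2 `COc1ccc(S(=O)(=O)/C(=C/c2ccc(C)s2)C(=O)c2ccc(Cl)cc2)cc1`: 25000 nM

Compound 2 holds the higher of the two numbers, beyond the scatter, and is the weaker growth inhibitor of the pair. Compound 3 `Cc1ccc(/C=C(\C(=O)c2ccc(Cl)cc2)S(=O)(=O)Cc2ccc(F)cc2)s1` differs from compound 2 in one place, with 4-fluorobenzyl in place of 4-methoxyphenyl on a sulfonyl sulfur. Among the measured compounds shown here, no measured pair shows this change, so any forecast in this assay is a judgement. A clear step towards a lower number is expected, since compound 2 at 25000 nM sits high and compound 1 at 1000 nM shows that much lower numbers occur. The expected step is an 8.3-fold lower number from compound 2 to compound 3 (0.92 log units; beyond the scatter). The estimate for compound 3 is 3000 nM, within a range of 600 nM to 15000 nM.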

Compound 3, concentration for 50% growth inhibition: 50000 nM
The estimate for compound 3 lay 17-fold (1.22 log units) below the measured number; measured number outside the range, above it.
By their numbers in this assay, from the lowest: compound 1; then compounds 2 and 3 (each within the scatter of the next).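

In this assay, exchanging the group on the sulfonyl sulfur gives a 2.0-fold higher number from compound 2 to compound 3 (0.30 log units; within the scatter) and so the two compounds cannot be told apart. Among the compounds shown here, this is the first one-place comparison at this position, and it shows that this exchange of two groups of equal heavy-atom count does not separate the compounds in this measure of growth inhibition. No measurement is available that would explain this result. Going by these compounds, whether an amine or a carboxylic acid on the sulfonyl sulfur would change the number remains open. So does whether the same exchange would give a similar result on a different core.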